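A few compounds are considered here, and "the series" means these few. Any claim that something is new, unique, unknown or untested is made for them only; others in the source may bear on it.

Measured compounds:
- compound 1, `Cc1cccc(C)c1NC(=O)NC1CCN(c2ncnc3[nH]ncc23)CC1`, with 2160 nM in an assay on isolated protein for inhibition of serine/threonine-protein kinase PAK 1 (Homo sapiens), read by ADP-Glo, with a stated time of 40 min; on this read-out higher numbers stand for weaker inhibition and lower numbers for stronger inhibition
- compound 2, `COc1ccc(NC(=O)NC2CCN(c3ncnc4[nH]ncc34)CC2)cc1`, with 6370 nM in this assay
- compound 3, `O=C(Nc1cccc(Cl)c1)NC1CCN(c2ncnc3[nH]ncc23)CC1`, with 1240 nM in this assay

Of the three, compound 3 gives the lowest number, yet only the gap to compound 2 is beyond the scatter: the step from compound 2 to compound 3 is a 5.1-fold lower number from compound 2 to compound 3 (0.71 log units; beyond the scatter), whereas the step from compound 1 to compound 3 is a 1.7-fold lower number from compound 1 to compound 3 (0.24 log units; within the scatter), within the scatter. Compound 4, `O=C(Nc1ccccc1Cl)NC1CCN(c2ncnc3[nH]ncc23)CC1`, has not been measured. It differs from compound 3 in one place: 2-chlorophenyl in place of 3-chlorophenyl on an amide-type nitrogen. Going by the values given here, no measured step moves a chlorine from one ring position to another, so nothing bears directly on it. The closest hint is compound 1, whose 2,6-dimethylphenyl group, carrying its substituents at the positions flanking the attachment, sits within the scatter of compound 3 because of a 1.7-fold lower number from compound 1 to compound 3 (0.24 log units; within the scatter). Substitution of the phenyl ring appears tolerated across the three compounds, with only compound 2 standing apart through a 2.9-fold higher number from compound 1 to compound 2 (0.47 log units; beyond the scatter). Compound 4 is therefore expected to change only within the scatter, with a step of a 1.5-fold higher number from compound 3 to compound 4 (0.16 log units; within the scatter). The estimate for compound 4 in this assay is 1800 nM, with a range from 700 nM to 4500 nM.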

Compound 4, half-maximal inhibitory concentration: 560 nM
Estimate against measurement, compound 4: 3.2-fold (0.51 log units) above; the measured number lies below the stated range.
By their numbers in this assay, from the lowest: compound 4; then compounds 3 and 1 (each within the scatter of the next); then compound 2.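

In this assay, going by these compounds alone, moving the chlorine on the same ring, with 2-chlorophenyl in place of 3-chlorophenyl on the amide-type nitrogen, gives a 2.2-fold lower number from compound 3 to compound 4 (0.35 log units; beyond the scatter) and so shows that the ring position of this one atom matters on its own, which the earlier compounds could not show because their rings also differed in the kind of substituent. Compound 4 also stands apart from the other two, with a 3.9-fold lower number from compound 1 to compound 4 (0.59 log units; beyond the scatter) and an 11-fold lower number from compound 2 to compound 4 (1.06 log units; beyond the scatter) in this series, which makes it the most potent of the four and shows that the earlier tolerance among substituted phenyl rings does not extend to this change. Nothing available explains why the 2-chlorophenyl group gives the lower number.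

Within the data shown here, only one pair of compounds moves a substituent while keeping it the same, so it remains open whether the gain belongs to chlorine or to any group at that ring position. A 2-fluorophenyl, 2-methoxyphenyl or 4-chlorophenyl group on the same nitrogen would separate these readings.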